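A Diastereomer of a Cyclic Peroxide Acid Awaits Testing

A few compounds are considered here, and "the series" means these few. Any claim that something is new, unique, unknown or untested is made for them only; others in the source may bear on it.

Three compounds have been examined in a functional assay on OVCAR-3 cells (Homo sapiens) for inhibition; a higher number here means a weaker inhibitor of growth, a lower number a stronger inhibitor of growth. Compound 1 `C=C1CCC[C@H]2[C@](C)(CCC(C)=O)[C@@H](C)CC[C@]12C` reaches only a limit of the assay, and in this assay compound 1 gives > 15000 nM. Compound 2 `CC1=C(CC/C(C)=C/CC[C@@]2(C)CC[C@@H]([C@H](C)C(=O)O)OO2)C(C)(C)CCC1` likewise reaches only a limit, and in this assay compound 2 gives > 100000 nM. Among the compounds with values here, compound 3 `C=C1CCCC(C)(C)C1CC[C@@]1(C)CC[C@H]([C@@H](C)C(=O)O)OO1` is the one member of the set with a measured number: in this assay compound 3 gives 2490 nM, which is therefore the only point of reference.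

Compound 4 `C=C1CCCC(C)(C)C1CC[C@]1(C)CC[C@@H]([C@@H](C)C(=O)O)OO1` has not yet been measured. It differs from compound 3 as follows: the two compounds have the same atoms and bonds; at least one stereo element is drawn with a configuration in one of them and without one in the other: 2 of 4 stereo elements differ; a stereocentre at a saturated ring carbon is drawn S in compound 3 and R in compound 4; a stereocentre at a saturated ring carbon is drawn R in compound 3 and S in compound 4. Within the data shown here, no step between two measured compounds is available, so nothing in the data shows how such a change at two ring stereocentres shifts growth inhibition. The step from compound 3 to compound 4 a 1.6-fold higher number from compound 3 to compound 4 (0.21 log units; within the scatter) is expected to be modest, though it could run in either direction and may reach beyond the usual scatter. For compound 4 the estimate in this assay is 4000 nM, with a range from 800 nM to 30000 nM, and a limit rather than a number is also possible.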

Compound 4, concentration for 50% growth inhibition: > 10000 nM
Compound 4: only a limit was reported; the forecaster's own chance of this, stated with the estimate: 25%; middle value at least 2.5-fold (0.39 log units) from the limit.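

In this assay compound 4 gives > 10000 nM, which is a limit of the assay and not a number. Within the data shown here, although the atoms and bonds stay the same, reversing the drawn configuration at two saturated ring carbons, one from S to R and the other from R to S, produces an at least 4.0-fold higher number from compound 3 to compound 4 (0.60 log units; beyond the scatter), so the earlier compounds' lack of any step between measured pairs now gives way to a first sign that the arrangement at these two ring stereocentres matters for growth inhibition in these cells. The full size of this step remains unfixed because the value for compound 4 ends at a limit: the limit of > 10000 nM in this assay, at which 1 of the 4 values shown sits.

The compounds shown leave open whether one of the two ring stereocentres accounts for the change or whether both contribute, since they change together in this single step. They also leave open whether a methyl ester or an amide in place of the carboxylic acid would retain the growth inhibition seen with compound 3, or how either of those groups would behave with the configuration of compound 4.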